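A few compounds are considered here, and "the series" means these few. Any claim that something is new, unique, unknown or untested is made for them only; others in the source may bear on it.

In a functional assay on HepG2 cells (Homo sapiens) for cytotoxicity, with a stated time of 72 h (on this read-out higher numbers stand for an effect only at larger amounts of compound and lower numbers for an effect already at smaller amounts), compound 3 (`C=C[C@@](C)(/C=C/c1ccc(O)cc1)CCC1OC1(C)C`) gives > 52000 nM as its reading, which is a limit of the assay and not a number. In the same test compound 1 (`C=C[C@@](C)(/C=C/c1ccc(OS(=O)(=O)C(F)(F)F)cc1)CCC=C(C)C`) gives > 52000 nM as its reading, also a limit. Compound 2 (`C=C[C@@](C)(/C=C/c1ccc(OS(=O)(=O)c2ccc(C)cc2)cc1)CCC=C(C)C`) gives > 52000 nM as its reading, again a limit.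

Going by the values given here, the only measured step in this small set is a step that the two limits leave unreadable from compound 1 to compound 2 and it concerns a group on a sulfonyl sulfur, not the chain changed here, so it offers no size to carry over. Among the compounds with values here, the whole record so far is the limit of > 52000 nM in this assay, at which 3 of the 3 values shown sit, and no compound here has yet given an actual number.

Compound 4 (`C=C[C@@](C)(/C=C/c1ccc(O)cc1)CCCO`) differs from compound 3 by one change (hydroxymethyl in place of 3,3-dimethyloxiran-2-yl on a saturated chain carbon, three bonds along the chain from two double-bonded chain carbons) in which hydroxymethyl stands in place of 3,3-dimethyloxiran-2-yl on a saturated chain carbon, three bonds along the chain from two double-bonded chain carbons.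

Compound 3 sits at > 52000 nM as a limit, so compound 4 is expected to stay in the same region, with no step beyond the scatter in either direction. The expected change is a step that the limit leaves unreadable from compound 3 to compound 4 and this remains a rough estimate. For compound 4 the estimate is 60000 nM with an expected range from 30000 nM to 120000 nM and the assay will probably report only a limit again.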

Compound 4, half-maximal effective concentration: > 52000 nM
Compound 4: no number, only a limit; the forecaster's own chance of this, stated with the estimate: 75%; the middle value lies beyond the limit too.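

In this assay compound 3 and compound 4 both stop at a limit of the assay and not at a number, so no step can be read for the change from 3,3-dimethyloxiran-2-yl to hydroxymethyl. The compounds shown leave open whether any change to the shared core gives an actual number in this assay and how large that number would be.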